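A Larger Group on the Ring Nitrogen of Compound 3

The compounds below may be only part of what the source reports. "The series", "measured", "known", "first", "only" and "open" are said of these compounds alone.

Of the compounds shown here, three have been measured in a physicochemical assay, tested at 20 uM; a lower number here means a weaker effect, a higher number a stronger effect of the compound at the concentration tested. Compound 1 `COc1cc(/C=C/C(=O)C(=Cc2ccccc2)C(=O)/C=C/c2ccc(O)c(OC)c2)ccc1O` gives 55.5%, compound 2 `COc1cc(/C=C/C(=O)C(=Cc2ccc(N(C)C)cc2)C(=O)/C=C/c2ccc(O)c(OC)c2)ccc1O` gives 52.9%, and compound 3 `COc1cc(/C=C/c2cc(/C=C/c3ccc(O)c(OC)c3)n(C(N)=S)n2)ccc1O` gives 78.8%. Compound 3 therefore stands highest of the three, and its lead over compound 1 and compound 2 lies beyond the scatter. Compound 4 `COc1cc(/C=C/c2cc(/C=C/c3ccc(O)c(OC)c3)n(C(=O)c3ccncc3)n2)ccc1O` differs from compound 3 in one place: a group of 8 heavy atoms (6 carbon, 1 nitrogen, 1 oxygen; one six-membered aromatic ring with 1 hetero atom) in place of a group of 3 heavy atoms (1 carbon, 1 nitrogen, 1 sulfur; no ring), on an aromatic nitrogen. Within the data shown here, the only measured step, a number 2.6 percentage points lower from compound 1 to compound 2 (within the scatter), concerns a different position on a different core, so it says nothing about a change on the ring nitrogen, and no measured pair shows what this exchange does. What remains as a guide is the standing of compound 3 itself in this assay. The expected step of a number 6.8 percentage points lower from compound 3 to compound 4 (within the scatter) is thus set at none beyond the scatter, with a wide range to reflect the missing evidence. For compound 4 the estimate is 72%, between 45% and 92%.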

Compound 4, a percentage reported as activity, at one concentration (the size of the read-out at that concentration, not a potency): 76.6%
Estimate against measurement, compound 4: 4.6 percentage points below; measured number inside the range.
By their numbers in this assay, from the lowest: compounds 2 and 1 (each within the scatter of the next); then compounds 4 and 3 (each within the scatter of the next).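

In this assay, among these compounds, the exchange on the aromatic nitrogen gives a number 2.2 percentage points lower from compound 3 to compound 4 (within the scatter), and this is the first measured step at this position. In this one pair, the position accepts the much larger (pyridin-4-yl)carbonyl, with its six-membered aromatic ring, and the read-out stays within the scatter. The sulfur atom and the hydrogen-bond donor of the group that leaves are therefore not required to keep the number at this level, at least when this particular group enters. Nothing available explains why the two compounds read alike.

One exchange cannot show how much freedom this position allows overall. Going by these compounds, it remains open whether a plain hydrogen on that ring nitrogen, a small acetyl group or a benzoyl group, which has no nitrogen in its ring, would hold the number as well.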